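Cytotoxicity of nitroimidazooxazoles with trifluoromethyl and trifluoromethoxy aryl groups

The compounds below may be only part of what the source reports. "The series", "measured", "known", "first", "only" and "open" are said of these compounds alone.

Three compounds were examined in an ADME assay on MRC5 cells (Homo sapiens) for cytotoxicity, read by fluorescence, with a stated time of 72 h; on this read-out lower numbers stand for stronger inhibition and higher numbers for weaker inhibition. Compound 1, `CC1(COc2ccc(OC(F)(F)F)cc2)Cn2cc([N+](=O)[O-])nc2O1`, carries a trifluoromethoxy group on its aryl ether; in this assay compound 1 reaches only the limit of > 64000 nM. Compound 2, `CC1(COc2ccc(C(F)(F)F)cc2)Cn2cc([N+](=O)[O-])nc2O1`, carries a trifluoromethyl group in the same place; in this assay compound 2 likewise reaches only the limit of > 64000 nM. The change trifluoromethoxy in place of trifluoromethyl on an aromatic carbon therefore gives a step that the two limits leave unreadable from compound 2 to compound 1, since both values sit at the limit of > 64000 nM in this assay, at which 2 of the 3 values shown sit.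

Compound 3, `O=[N+]([O-])c1cn2c(n1)OC(COc1ccc(-c3ccc(C(F)(F)F)cc3)cn1)C2`, is built on a different core, and the difference between the two cores is not broken down here. In this assay, going by the values given here, compound 3 gives 45000 nM, the only value of the three that is a number rather than a limit.

Compound 4, `O=[N+]([O-])c1cn2c(n1)OC(COc1ccc(-c3ccc(OC(F)(F)F)cc3)cn1)C2`, has not yet been measured in this assay. It differs from compound 3 by trifluoromethoxy in place of trifluoromethyl on an aromatic carbon. This is the same change that was made from compound 2 to compound 1, and the two place descriptions agree word for word, so the earlier step is the nearest guide; it could not be read because both of its values sit at the limit. Among the compounds with values here, the expectation for compound 4 is therefore a step of a 1.2-fold higher number from compound 3 to compound 4 (0.09 log units; within the scatter), that is, a value close to the one measured for compound 3, since compound 3 gives 45000 nM. Compound 4 is accordingly estimated at 55000 nM, in a range from 28000 nM to 110000 nM, with a real chance that the assay again reports only a limit.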

Compound 4, half-maximal inhibitory concentration: 47000 nM
For compound 4 the middle estimate is 1.2-fold (0.07 log units) above the measured one; low and high end bracket the measured number.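

In this assay the change of trifluoromethyl to trifluoromethoxy on an aromatic carbon gives a 1.0-fold higher number from compound 3 to compound 4 (0.02 log units; within the scatter), so on this core the two groups cannot be told apart in this read-out. The same change on the other core, the step from compound 2 to compound 1, cannot be read, and a comparison between the two cores therefore has nothing to work with, because both of those compounds give a limit and not a number: the limit of > 64000 nM in this assay, at which 2 of the 4 values shown sit. The result thus shows that the change is tolerated on one core, in a single pair that sits near the top of the range shown, but it does not show that the change carries over from one core to the other, nor that the two groups would match on any further core.

The compounds shown leave open how the read-out would respond to a different group in the same place, such as an amine or a carboxylic acid, since only trifluoromethyl and trifluoromethoxy appear there. They also leave open what the core contributes by itself, as no pair shown differs in the core alone.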